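From methyl to bromo on an aromatic carbon

The compounds below may be only part of what the source reports. "The series", "measured", "known", "first", "only" and "open" are said of these compounds alone.

In a functional assay on SW1573 cells (Homo sapiens) for inhibition, read by sulforhodamine B assay, with a stated time of 48 h (on this read-out lower numbers stand for stronger inhibition of growth and higher numbers for weaker inhibition of growth), compound 1 `COC(=O)[C@@]1(C)CCC=C2[C@@H]1CC[C@@H](C)[C@]2(C)Cc1c[nH]c2ccccc12` gives 7300 nM, and compound 2 `COC(=O)[C@@]1(C)CCC=C2[C@@H]1CC[C@@H](C)[C@]2(C)Cc1c[nH]c2ccc(C)cc12` gives 15000 nM, the higher of the two numbers. Going by the values given here, the only measured step, a 2.1-fold higher number from compound 1 to compound 2 (0.31 log units; beyond the scatter), sits on the same aromatic carbon. Compound 3 `COC(=O)[C@@]1(C)CCC=C2[C@@H]1CC[C@@H](C)[C@]2(C)Cc1c[nH]c2ccc(Br)cc12` differs from compound 2 by bromo in place of methyl on an aromatic carbon. Among the compounds with values here, no measured step compares bromo with methyl, so the hydrogen-to-methyl step offers only weak guidance, and one single-atom group replaces another. The expected step is therefore a 1.3-fold lower number from compound 2 to compound 3 (0.10 log units; within the scatter), not beyond the scatter. Compound 3 is estimated at 12000 nM, with a range from 5000 nM to 35000 nM.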

Compound 3, concentration for 50% growth inhibition: 12000 nM
Estimate against measurement, compound 3: no gap at the digits printed; low and high end bracket the measured number.
By their numbers in this assay, from the lowest: compounds 1, 3 and 2 (each within the scatter of the next, the first and the last beyond it).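

In this assay, bromo and methyl on this aromatic carbon cannot be told apart, with a 1.3-fold lower number from compound 2 to compound 3 (0.10 log units; within the scatter). Bromo in place of hydrogen gives a 1.6-fold higher number from compound 1 to compound 3 (0.22 log units; within the scatter), so compound 3 lies within the scatter of both compound 1 and compound 2, even though those two differ beyond it. No available evidence explains this result.

From the compounds shown here alone, whether an amine or a carboxylic acid on this carbon would move the number further remains open. So does the effect of a longer chain here.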